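The source may report more compounds than this note shows. Statements on the series, on what has been measured and on what is new or still open speak of the compounds shown alone.

Measured in a functional assay on HeLa cells (Homo sapiens) for inhibition; on this read-out higher numbers stand for weaker inhibition and lower numbers for stronger inhibition:
Compound 1 (`O=C(CC(CC(=O)NC1Cc2ccccc2C1)c1ccc(Cl)cc1)NCCN1CCCC1`): 77300 nM
Compound 2 (`O=C(CC(CC(=O)NC1Cc2ccccc2C1)c1ccccc1)NCCN1CCCCC1`): > 100000 nM (a limit of the assay, not a number)

Compound 2 has no number to work from, only a limit: the limit of > 100000 nM in this assay, at which 1 of the 2 values shown sits. Among the measured compounds shown here, compound 1 is the only compound in this small set with a number (77300 nM), and that number still reflects weak inhibition in this assay.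

The next compound to be read is compound 3 (`O=C(CC(CC(=O)NC1Cc2ccccc2C1)c1ccccc1)NCCN1CCCC1`). It carries pyrrolidin-1-yl in place of piperidin-1-yl on a saturated chain carbon, two bonds along the chain from an amide-type nitrogen. The change stays within the same side chain and leaves the rest of the structure untouched. For the measured compounds named here, no measured pair shows this change on its own, so any forecast for it remains tentative.

With only a limit as the starting point, no firm direction can be given, and a shift no greater than the usual scatter is expected. The expected size of the change is an at least 1.1-fold lower number from compound 2 to compound 3 (0.04 log units; that floor lies within the scatter). Weak inhibition is therefore expected again, and the assay may again return only a limit. Compound 3 is estimated at 90000 nM, with an expected range from 45000 nM to 180000 nM.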

Compound 3, half-maximal inhibitory concentration: > 100000 nM
Compound 3: no number, only a limit; the forecaster's own chance of this, stated with the estimate: 50%; at least 1.1-fold (0.04 log units) between middle value and limit.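

In this assay compound 3 returns a limit of the assay and not a number: > 100000 nM. Compound 2 also returned only a limit, so the step for pyrrolidin-1-yl in place of piperidin-1-yl on a saturated chain carbon cannot be read, and nothing can be said about the direction or size of this change. Hydrogen in place of chloro on an aromatic carbon is the one change here that can be read, as an at least 1.2-fold higher number from compound 1 to compound 3 (0.11 log units; that floor lies within the scatter); only a floor is known, so the true size of this step stays undetermined, and most of this small set now sits at the top of the measurable range: the limit of > 100000 nM in this assay, at which 2 of the 3 values shown sit.

Still open, going by these compounds, is whether any other group on this chain gives a number in this assay, for example morpholin-4-yl or dimethylamino in place of pyrrolidin-1-yl, or a longer chain carrying the same pyrrolidin-1-yl. Equally open, on these data alone, is whether bromo or trifluoromethyl in place of chloro on that aromatic carbon would separate from compound 1 by more than the usual scatter.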